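The compounds below may be only part of what the source reports. "The series", "measured", "known", "first", "only" and "open" are said of these compounds alone.

In an ADME assay on cells (Homo sapiens) for cytotoxicity, read by resazurin assay, with a stated time of 5 days (a higher number here means that more compound is tolerated, a lower number that less compound is tolerated), three compounds of this series have been measured so far. Compound 1 `COc1ccc(-c2nc(CNc3cccc(Cl)c3)nc3ccsc23)cn1` gives > 50000 nM, which is a limit of the assay rather than a number. Compound 3 `COc1ccc(-c2nc(CCc3cccc(Cl)c3)nc3ccsc23)cn1` gives > 50000 nM, again a limit. Among the measured compounds shown here, the only single-point step among the measured pair, a step that the two limits leave unreadable from compound 1 to compound 3, cannot be read because both ends sit at the limit. Compound 2 `O=S(=O)(Cc1nc(-c2ccncc2)c2sccc2n1)c1cccc(Cl)c1` gives > 50000 nM, also a limit, so its standing on the numbers is known only as a limit, and the same holds for the two other values shown, as the limit of > 50000 nM in this assay, at which 3 of the 3 values shown sit, records.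

Compound 4 `O=S(=O)(Cc1nc(-c2ccoc2)c2sccc2n1)c1cccc(Cl)c1` differs from compound 2 in one place: furan-3-yl in place of pyridin-4-yl on an aromatic carbon. For the measured compounds named here, no measured step bears on this change, and the one measured step is unreadable. The expected step of a number no higher from compound 2 to compound 4 (the limit leaves the size open) is therefore none beyond the scatter, with the expectation that the reading again comes back as a limit. For compound 4 the estimate in this assay is 50000 nM, with a range from 20000 nM to 120000 nM.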

Compound 4, half-maximal cytotoxic concentration: > 50000 nM
Compound 4: a limit, no number; the forecaster's own chance of this, stated with the estimate: 80%; the middle value sits exactly at the limit.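

Compound 2 and compound 4 both give a limit rather than a number, so the step between them, furan-3-yl in place of pyridin-4-yl, cannot be read: the limit of > 50000 nM in this assay, at which 4 of the 4 values shown sit.

The compounds shown leave open at what concentration any of them becomes cytotoxic in this assay, and whether any of these changes shifts that concentration.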